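A few compounds are considered here, and "the series" means these few. Any claim that something is new, unique, unknown or untested is made for them only; others in the source may bear on it.

In an in vitro assay on BTI-TN-5B1-4 cells for inhibition of sterol O-acyltransferase 2 (Homo sapiens), tested at 50 uM (on this read-out higher numbers stand for more inhibition at the one concentration tested (going by the name of the read-out) and lower numbers for less inhibition), the three measured compounds stand as follows.
Compound 1, `CCCCCCCCNc1cccc(-c2ccccc2)c1`, gives -20%.
Compound 2, `CCCCCCCCNc1ccc(-c2ccccc2)cc1`, gives 6%.
Compound 3, `CCCCCCCCCNc1cccc(-c2ccccc2)c1`, gives -8%.

Compound 3 differs from compound 1 by methyl in place of hydrogen on a saturated chain carbon, eight bonds along the chain from a nitrogen on an aromatic ring, and that step gave a number 12 percentage points higher from compound 1 to compound 3 (beyond the scatter). How the core of compound 2 differs from the core of compound 1 is not broken down here; compound 2 nonetheless stands highest of the three, its gaps to compound 3 and to compound 1 both lying beyond the usual scatter.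

Compound 4, `CCCCCCCCCNc1ccc(-c2ccccc2)cc1`, has not yet been measured. It differs from compound 2 by methyl in place of hydrogen on a saturated chain carbon, eight bonds along the chain from a nitrogen on an aromatic ring, the same change as from compound 1 to compound 3. Because that earlier step gave a number 12 percentage points higher from compound 1 to compound 3 (beyond the scatter), a step of similar size is expected here, namely a number 12 percentage points higher from compound 2 to compound 4 (beyond the scatter). Compound 4 is therefore expected to give about 18% in this assay, with an estimated range from 2% to 34%.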

Compound 4, a percentage reported as inhibition, at one concentration (the size of the read-out at that concentration, not a potency): 18%
Compound 4: middle estimate and measured number agree at the digits printed; the range from low to high includes it.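

In this assay, the added methyl gave a number 12 percentage points higher from compound 2 to compound 4 (beyond the scatter). Set beside the earlier step, the change carries over between the two cores with no difference in size: the same change on two cores in this assay, a number 12 percentage points higher (beyond the scatter) from compound 1 to compound 3 and a number 12 percentage points higher (beyond the scatter) from compound 2 to compound 4, 0 percentage points apart, within the scatter of two such steps. This rests on one change on two cores, read as percentages at one concentration, so it says nothing about potency or about whether the step would hold on any other core.

The compounds shown leave open whether a longer chain would raise the number further or whether the rise stops at some chain length. They also leave open what a carboxylic acid or an amine in place of the methyl would do.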